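A few compounds are considered here, and "the series" means these few. Any claim that something is new, unique, unknown or untested is made for them only; others in the source may bear on it.

Working notes on a small chalcone-type series built on the core of compound 1 `COc1ccc(-c2cc3ccccc3nc2C=O)cc1`. In a functional assay on MCF7 cells (Homo sapiens) for antiproliferative activity, read by XTT assay, with a stated time of 72 h (a higher number here means a weaker inhibitor, a lower number a stronger inhibitor), compound 1 returns only a limit, > 10000 nM; this is the limit at which one of the two shown values sits, (the limit of > 10000 nM in this assay, at which 1 of the 2 values shown sits). Among the measured compounds shown here, compound 2 `COc1ccc(-c2cc3ccccc3nc2/C=C/C(=O)c2ccc([N+](=O)[O-])cc2)cc1` carries the extended enone arm and is the only compound with a number in this assay, 4110 nM. Compound 3 `COc1ccc(-c2cc3ccccc3nc2/C=C/C(=O)c2ccsc2)cc1` differs from compound 2 by thiophen-3-yl in place of 4-nitrophenyl on a carbonyl carbon, a thiophen-3-yl in place of 4-nitrophenyl on a carbonyl carbon. For the measured compounds named here, no measured step covers this exchange, so the expected step of a 1.2-fold higher number from compound 2 to compound 3 (0.09 log units; within the scatter) is put at no change beyond the usual scatter. For compound 3 the estimate in this assay is 5000 nM, with a range from 1800 nM to 14000 nM.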

Compound 3, half-maximal inhibitory concentration: 6010 nM
Beside the measured number, compound 3's estimate is 1.2-fold (0.08 log units) below it; the range from low to high includes it.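

With thiophen-3-yl in place of 4-nitrophenyl on the carbonyl carbon, this assay gives a 1.5-fold higher number from compound 2 to compound 3 (0.17 log units; within the scatter), so this position takes a five-membered aromatic ring with sulfur as well as a six-membered carbon ring without a change beyond the scatter. Replacing formyl with the thiophen-3-yl enone arm gives an at least 1.6-fold lower number from compound 1 to compound 3 (0.22 log units; that floor lies within the scatter), and that floor alone establishes no gain. Compound 1 stands only at a limit: the limit of > 10000 nM in this assay, at which 1 of the 3 values shown sits.

Still open, from the compounds shown here alone, is whether an amine, a carboxylic acid or a longer chain on this carbonyl carbon would move the number beyond the scatter.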